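This account rests on a few compounds, and the source may have more. Where it says the series, first, only, none or still open, it means among the compounds named here.

Compound 3 `COc1ccc2nc(C)cc(OCC(=O)Nc3cc(C)nc(C)n3)c2c1` stands lowest of the three compounds measured in a physicochemical assay for solubility, in phosphate buffer, measured as kinetic solubility, with a stated time of 1 h, at pH 7.4 (a higher number here means a more soluble compound, a lower number a less soluble compound), where compound 3 gives 5000 nM. Compound 1 `COc1ccc2nc(C)cc(OCC(=O)Nc3cc(F)cc(F)c3)c2c1` gives 13000 nM, and compound 2 `COc1ccc2nc(C)cc(OCC(=O)Nc3ccncc3)c2c1` gives 91500 nM. The measured steps among them are a 7.0-fold higher number from compound 1 to compound 2 (0.85 log units; beyond the scatter), a 2.6-fold lower number from compound 1 to compound 3 (0.41 log units; beyond the scatter) and an 18-fold lower number from compound 2 to compound 3 (1.26 log units; beyond the scatter). Compound 4 `COc1ccc2nc(C)cc(OCC(=O)NNC(=O)c3ccncc3)c2c1` has not yet been measured in this assay; it differs from compound 3 in one place: ((pyridin-4-yl)carbonyl)amino in place of 2,6-dimethylpyrimidin-4-yl on an amide-type nitrogen. The step that bears most on this change is an 18-fold lower number from compound 2 to compound 3 (1.26 log units; beyond the scatter), since compound 2 carries the same pyridin-4-yl ring that enters with compound 4, although in compound 4 that ring is joined through a carbonyl and a further nitrogen to the amide-type nitrogen. Among the compounds with values here, no measured step covers that carbonyl-amino link itself, so the size of its own contribution is unknown. A step upward, large rather than modest, is nonetheless expected because compound 2 gives 91500 nM with the same ring. Compound 4 is therefore expected to show a step of a 12-fold higher number from compound 3 to compound 4 (1.08 log units; beyond the scatter) in this assay. Compound 4 is estimated at 60000 nM, within a range of 15000 nM to 200000 nM.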

Compound 4, solubility: >= 375000 nM
Compound 4 gave a limit, no number (the forecaster's own chance of this, stated with the estimate: 10%); at least 6.2-fold (0.79 log units) between middle value and limit.
By their numbers in this assay, from the lowest: compound 3; then compound 1; then compound 2. At a limit, above all of these: compound 4.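

In this assay compound 4 gives a limit and not a number: the limit of >= 375000 nM in this assay, at which 1 of the 4 values shown sits.

Read as minimum steps, an at least 75-fold higher number from compound 3 to compound 4 (1.87 log units; beyond the scatter) and an at least 28-fold higher number from compound 1 to compound 4 (1.46 log units; beyond the scatter) are both large, and they place ((pyridin-4-yl)carbonyl)amino on the amide-type nitrogen past every other group measured there. Within the data shown here, the comparison the earlier compounds could not offer is an at least 4.0-fold higher number from compound 2 to compound 4 (0.61 log units; beyond the scatter), in which the pyridin-4-yl ring stands on both sides, so the rise beyond the scatter goes with the added carbonyl and further nitrogen and not with the ring alone.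

From the compounds shown here alone, how far compound 4 lies past its limit remains unknown, so the full size of all three steps stays unfixed. Going by these compounds, it is also open whether this rise depends on the pyridin-4-yl ring or on the link itself: a benzoyl group on the same further nitrogen would separate the two, and an acetyl group there would show what the link does with no ring attached.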